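Benzhydrazone series: aryl swap toward thiophen-2-yl

The source may report more compounds than this note shows. Statements on the series, on what has been measured and on what is new or still open speak of the compounds shown alone.

Three hydrazones sharing the dibenzylhydrazone core have been measured in an assay on liver (Sus scrofa) for inhibition of glucose-6-phosphatase catalytic subunit 1 (Homo sapiens), using microsomes; a lower number here means a stronger inhibitor, a higher number a weaker inhibitor. Compound 1 `Oc1ccc(/C=N/N(Cc2ccccc2)Cc2ccccc2)cc1` gives 2400 nM. Compound 2 `Clc1cc(Cl)cc(/C=N/N(Cc2ccccc2)Cc2ccccc2)c1` reaches only the assay limit of > 100000 nM, a limit and not a number (the limit of > 100000 nM in this assay, at which 1 of the 3 values shown sits). Compound 3 `Clc1ccc(/C=N/N(Cc2ccccc2)Cc2ccccc2)cc1Cl` gives 2000 nM, the lowest of the two numbers, with compound 1 nearest and within the scatter of it.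

The aryl group on the carbon with a double bond to nitrogen is the only site varied. Moving from compound 1 to compound 3 changes little a 1.2-fold lower number from compound 1 to compound 3 (0.08 log units; within the scatter), whereas an at least 50-fold lower number from compound 2 to compound 3 (1.69 log units; beyond the scatter) is large, so the pattern of substitution on that aryl group can shift this assay strongly in either direction.

Compound 4 `C(=N/N(Cc1ccccc1)Cc1ccccc1)\c1cccs1` carries thiophen-2-yl in place of 3,4-dichlorophenyl on a carbon with a double bond to nitrogen. Going by the values given here, no measured step exchanges a six-membered aryl for a five-membered heteroaryl here, so the bearing of the measured steps is indirect: they show only that this position is sensitive. For compound 4 a moderate weakening is expected, 6000 nM with a range from 1500 nM to 30000 nM. The expected step is a 3.0-fold higher number from compound 3 to compound 4 (0.48 log units; beyond the scatter).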

Compound 4, half-maximal inhibitory concentration: 1500 nM
Compound 4: middle estimate off by 4.0-fold (0.60 log units), on the high side, and the stated range covers the measured number.
By their numbers in this assay, from the lowest: compounds 4, 3 and 1 (each within the scatter of the next). At a limit, above all of these: compound 2.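

In this assay, the five-membered thiophen-2-yl ring holds its place among the six-membered aryl groups on a carbon with a double bond to nitrogen, as shown by a 1.3-fold lower number from compound 3 to compound 4 (0.12 log units; within the scatter) and by a 1.6-fold lower number from compound 1 to compound 4 (0.20 log units; within the scatter). Going by these compounds alone, neither the two chlorine atoms of compound 3 nor the hydroxyl group of compound 1 is therefore required at this position, and a six-membered ring of carbon only is not required either, while an at least 66-fold lower number from compound 2 to compound 4 (1.82 log units; beyond the scatter) shows that compound 2 remains the one compound that departs from the other three. That last step is read against a limit and not a number: the limit of > 100000 nM in this assay, at which 1 of the 4 values shown sits.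

The compounds shown leave open whether the loss seen with 3,5-dichlorophenyl belongs to that substitution pattern alone or would recur with other groups placed the same way on the ring. On these data alone, how far this position accepts other five-membered rings, such as furan-2-yl or thiazol-2-yl, or a ring carrying an amine or a carboxylic acid, also remains open.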